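From a carbamoyl to a naphthalenyl on the chain

A few compounds are considered here, and "the series" means these few. Any claim that something is new, unique, unknown or untested is made for them only; others in the source may bear on it.

Measured compounds:
compound 1 `N=C(N)Nc1cccc(C(=O)NNC(=O)NC(CC(=O)O)C(N)=O)c1` with -2.42
compound 2 `CC(=N)Nc1cccc(C(=O)NNC(=O)CC(CC(=O)O)c2ccc(Br)cc2)c1` with 2.27

In a physicochemical assay for lipophilicity (on this read-out higher numbers stand for higher lipophilicity and lower numbers for lower lipophilicity), compound 1 gives -2.42, the lower of the two measured numbers. Compound 2 `CC(=N)Nc1cccc(C(=O)NNC(=O)CC(CC(=O)O)c2ccc(Br)cc2)c1` gives 2.27 in this assay, a value well above that of compound 1, and the gap between the two is beyond the scatter of the measurement. Among the compounds with values here, no pair of measured compounds differing in one place is available, so no single step can be quoted.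

The step of interest leads from compound 1 to compound 3 `N=C(N)Nc1cccc(C(=O)NNC(=O)NC(CC(=O)O)c2cccc3ccccc23)c1`, not yet measured. It brings (naphthalen-1-yl in place of carbamoyl on a saturated chain carbon bound to an amide-type nitrogen and a saturated chain carbon). Within the data shown here, no measured pair shows this exact change; the expectation is a large rise in this assay, far beyond the scatter, so that compound 3 is expected to land closer to compound 2 than to compound 1. The step from compound 1 to compound 3 is estimated at a number 3.72 log units higher from compound 1 to compound 3 (beyond the scatter). Compound 3 is estimated at 1.3, between 0.3 and 2.3.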

Compound 3, partition coefficient: 1.7
Beside the measured number, compound 3's estimate is 0.40 log units below it, within the range that was stated.
By their numbers in this assay, from the lowest: compound 1; then compound 3; then compound 2.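

In this assay, naphthalen-1-yl in place of carbamoyl on a saturated chain carbon bound to an amide-type nitrogen and a saturated chain carbon gives a number 4.12 log units higher from compound 1 to compound 3 (beyond the scatter). Within the data shown here, this is the first step here that differs in only one place, so this large shift can be assigned to this single exchange, in which a group with one hydrogen-bond donor and one acceptor gives way to a group of carbon only, in two aromatic rings, with neither. Nothing available explains the size of this shift.

A single step cannot separate the effect of losing the carbamoyl from that of adding the naphthalen-1-yl. On these data alone, how the number responds to a small methyl group, or to a cyclohexyl ring with no aromatic ring, on the same carbon remains open.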